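The source may hold more compounds than are shown below. What is called first, only, known or untested is meant among the compounds shown, and "the series" means these compounds.

Measured in a functional assay on HL-60 cells (Homo sapiens) for cytotoxicity, read by MTT assay, with a stated time of 48 h; on this read-out higher numbers stand for weaker inhibition and lower numbers for stronger inhibition:
- Compound 1 `C[C@@H](C(=O)O)c1c([C@@]2(C)CCCC(C)(C)C2)ccc2c1CN(CCN)C2=O` gives > 10000 nM
- Compound 2 `CCC(C)CN1Cc2c(ccc([C@@]3(C)CCCC(C)(C)C3)c2[C@@H](C)C(=O)O)C1=O` gives > 10000 nM

Compound 2 has no exact number, since its > 10000 nM is a limit of the assay. Compound 1 likewise shows only a limit, its > 10000 nM in the list above.

Compound 3 `COC(=O)CN1Cc2c(ccc([C@@]3(C)CCCC(C)(C)C3)c2[C@@H](C)C(=O)O)C1=O` differs from compound 2 at one place, with methoxycarbonyl in place of sec-butyl on a saturated chain carbon bound to an amide-type nitrogen in a ring as the full difference. Among the measured compounds shown here, the one measured step at this place is a step that the two limits leave unreadable from compound 1 to compound 2, and it offers no size to carry over. Compound 1 and compound 2 both sit at the limit of > 10000 nM in this assay, at which 2 of the 2 values shown sit, so no direction can be read from them. No step beyond the scatter is therefore expected in this assay, and compound 3 is expected to stay close to that limit. The expected step is a step that the limit leaves unreadable from compound 2 to compound 3 as an estimate only. For compound 3 the estimated value is 12000 nM, with an expected range from 5000 nM to 30000 nM as its spread.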

Compound 3, half-maximal inhibitory concentration: > 10000 nM
Compound 3: no number, only a limit; the forecaster's own chance of this, stated with the estimate: 80%; the middle value is on the limit's open side.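

In this assay compound 3 shows only a limit, as compound 1 and compound 2 do, so no step among these three compounds can be read: the limit of > 10000 nM in this assay, at which 3 of the 3 values shown sit. The compounds shown leave open how strongly each one acts on these cells, and whether the changed group matters at all.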